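From compound 1 to compound 3: a ring methyl gives way

The source may report more compounds than this note shows. Statements on the series, on what has been measured and on what is new or still open speak of the compounds shown alone.

In an ADME assay on a cell-free system (plasma, Homo sapiens) for metabolic stability, with Plasma (Rattus norvegicus) as the target, read by HPLC (on this read-out higher numbers stand for a longer-lived compound and lower numbers for a shorter-lived compound), compound 1 `COc1cc(NC(C)CCCN2C(=O)[C@@H](C)N(C(=O)CN)C2(C)C)c2ncccc2c1` stands at > 3 h as a limit of the assay, not a number. Compound 2 `COc1cc(NC(C)CCCN2C(=O)CN(C(=O)[C@H](N)CC(C)C)C2(C)C)c2ncccc2c1` gives > 3 h as a limit as well. The data so far thus amount to the limit of > 3 h in this assay, at which 2 of the 2 values shown sit, and offer no exact half-life for either compound.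

Compound 3 `COc1cc(NC(C)CCCN2C(=O)CN(C(=O)CN)C2(C)C)c2ncccc2c1` departs from compound 1 by a single change hydrogen in place of methyl on a saturated ring carbon. Compound 2 also lacks that methyl, though it carries a different side chain, and its reading is the limit > 3 h of the assay. No shift beyond the usual scatter is therefore expected in this assay in either direction. The estimated step that the limit leaves unreadable from compound 1 to compound 3 stays within that scatter. Compound 3 is expected at 5 h, within an estimated range of 2 h to 14 h in this measurement.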

Compound 3, half-life in the Plasma assay: > 3 h
Compound 3: no number, only a limit; the forecaster's own chance of this, stated with the estimate: 65%; the middle value lies beyond the limit too.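

In the Plasma assay compound 3 gives > 3 h, which is a limit of the assay and not a number. No step can be read from compound 1 or compound 2 to compound 3 in the Plasma assay, where all three compounds give only a limit: the limit of > 3 h in the Plasma assay, at which 3 of the 3 values shown sit. The compounds shown leave open the exact half-life of each compound and whether replacing the methyl or the isobutyl with hydrogen shifts it. In a physicochemical assay for solubility (a higher number here means a more soluble compound, a lower number a less soluble compound), compound 1 gives 110000 ug/mL and compound 3 gives 150000 ug/mL. These two values lie within the usual scatter of each other.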